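Pyrazolylaminomethylene pyrazolones: methylpyrazole swap on the phenyl series

This account rests on a few compounds, and the source may have more. Where it says the series, first, only, none or still open, it means among the compounds named here.

Measured so far in a functional assay on MDA-MB-361 cells (Homo sapiens) for antiproliferative activity, read by MTT assay, with a stated time of 72 h; on this read-out higher numbers stand for weaker inhibition and lower numbers for stronger inhibition:
compound 1 `CCOC(=O)c1c[nH]nc1N/C=C1\C(=O)NN=C1c1ccccc1` gives 121000 nM
compound 2 `Cc1cc(N/C=C2\C(=O)NN=C2c2ccccc2)n[nH]1` gives 96100 nM
compound 3 `CCOC(=O)c1c[nH]nc1N/C=C1\C(=O)N(c2ccccc2)N=C1c1ccccc1` gives 24700 nM

Compound 3 stands lowest of the three numbers in this assay. Its nearest neighbour is compound 2, and the gap to it is beyond the scatter; the gap to compound 1 is wider still. Within the data shown here, the only single-point step measured so far is a 4.9-fold lower number from compound 1 to compound 3 (0.69 log units; beyond the scatter), which goes with phenyl in place of hydrogen on the ring amide nitrogen.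

Compound 4 `Cc1cc(N/C=C2\C(=O)N(c3ccccc3)N=C2c2ccccc2)n[nH]1` has not been measured. It differs from compound 3 by 5-methyl-1H-pyrazol-3-yl in place of 4-(ethoxycarbonyl)-1H-pyrazol-3-yl on an amine nitrogen. The same exchange of pyrazolyl groups is seen between compound 1 and compound 2, both carrying hydrogen on the amide nitrogen; their two values lie within the scatter of each other, so that pair gives no sign of a step in either direction. Among the measured compounds shown here, no measured step covers this exchange with phenyl already present. Compound 4 is therefore expected to sit close to compound 3, with the step of a 1.2-fold lower number from compound 3 to compound 4 (0.09 log units; within the scatter) not expected to exceed the scatter. The estimate for compound 4 in this assay is 20000 nM, within a range of 8000 nM to 50000 nM.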

Compound 4, half-maximal inhibitory concentration: 9980 nM
Estimate against measurement, compound 4: 2.0-fold (0.30 log units) above; low and high end bracket the measured number.
By their numbers in this assay, from the lowest: compound 4; then compound 3; then compounds 2 and 1 (each within the scatter of the next).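

With phenyl on the ring amide nitrogen, the exchange of pyrazolyl groups on the amine nitrogen gives a step that can be read in this assay: a 2.5-fold lower number from compound 3 to compound 4 (0.39 log units; beyond the scatter). The same exchange with hydrogen on that nitrogen, in compounds 1 and 2, left two values within the scatter of each other, so the advantage of 5-methyl-1H-pyrazol-3-yl over 4-(ethoxycarbonyl)-1H-pyrazol-3-yl appears only in the phenyl pair. The phenyl change itself can now be read with a second pyrazolyl group, a 9.6-fold lower number from compound 2 to compound 4 (0.98 log units; beyond the scatter), and its size holds up across the two pairs: the same change on two cores in this assay, a 4.9-fold lower number (0.69 log units; beyond the scatter) from compound 1 to compound 3 and a 9.6-fold lower number (0.98 log units; beyond the scatter) from compound 2 to compound 4, 2.0-fold (0.29 log units) apart, within the scatter of two such steps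

The exchange alters two things at once, since the methyl group enters and the ethoxycarbonyl group leaves, so the compounds shown do not tell which of these goes with the lower number in compound 4. A carboxylic acid in place of the ethoxycarbonyl group, a longer chain in place of the methyl group, or a benzyl group in place of phenyl on the ring amide nitrogen would each test one of these changes alone.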